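This account rests on a few compounds, and the source may have more. Where it says the series, first, only, none or still open, it means among the compounds named here.

Compound 1 `N#C/C(=C\c1c(F)c(F)c(F)c(F)c1F)C(=O)c1c[nH]c2ccccc12`: 19000 nM; compound 2 `COc1ccc(CNC(=O)/C(C#N)=C/c2ccc[nH]2)cc1`: > 50000 nM.

In a functional assay on A-431 cells (Homo sapiens) for inhibition, read by MTT assay, with a stated time of 72 h (on this read-out higher numbers stand for weaker inhibition of growth and lower numbers for stronger inhibition of growth), compound 1 gives 19000 nM. For compound 2 the read-out is only a limit, > 50000 nM, which is the limit of > 50000 nM in this assay, at which 1 of the 2 values shown sits. Compound 3 `COc1ccc(CNC(=O)/C(C#N)=C/c2ccc(C)o2)cc1` differs from compound 2 by 5-methylfuran-2-yl in place of 1H-pyrrol-2-yl on a double-bonded chain carbon bound to a double-bonded chain carbon. Among the measured compounds shown here, no measured pair covers this change, so no direction can be drawn from the two values shown, and the expected step in this assay is none beyond the usual scatter. Compound 3 is estimated at 60000 nM, with a range from 15000 nM to 200000 nM. The expected step that the limit leaves unreadable from compound 2 to compound 3 stays within the scatter, and a limit rather than a number is the more likely outcome.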

Compound 3, concentration for 50% growth inhibition: 58000 nM
Compound 3: the middle estimate sits 1.0-fold (0.01 log units) above what was measured; the range from low to high includes it.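

No step can be read from compound 2 to compound 3, since compound 2 has only a limit: the limit of > 50000 nM in this assay, at which 1 of the 3 values shown sits.

The compounds shown leave open whether 5-methylfuran-2-yl in place of 1H-pyrrol-2-yl changes growth inhibition at all.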